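This account rests on a few compounds, and the source may have more. Where it says the series, first, only, none or still open, it means among the compounds named here.

Measured compounds:
compound 1 `COc1ccccc1Nc1nc(-c2cccc(F)c2)nc2ccc(F)cc12` — > 50000 nM (a limit)
compound 2 `Fc1cccc(Nc2nc(-c3cccc(F)c3)nc3ccc(F)cc23)c1` — 42300 nM

In a functional assay on U-937 cells (Homo sapiens) for cytotoxicity, read by MTT assay, with a stated time of 48 h (a lower number here means a stronger inhibitor, a higher number a weaker inhibitor), compound 1 gives only a limit, > 50000 nM. Among the measured compounds shown here, compound 2 gives 42300 nM in this assay, the only true number among the two values shown. The step of an at least 1.1-fold lower number from compound 1 to compound 2 (0.07 log units; that floor lies within the scatter) rests on that limit of > 50000 nM in this assay, at which 1 of the 2 values shown sits, and so cannot be sized beyond its floor, which lies within the scatter.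

Compound 3 `Fc1cccc(-c2nc(Nc3cccc(Cl)c3)c3cc(F)ccc3n2)c1` differs from compound 2 by chloro in place of fluoro on an aromatic carbon. For the measured compounds named here, no measured step bears directly on a chloro-for-fluoro exchange; the single step measured was a different exchange on the nitrogen and itself gave no usable size. Compound 3 is therefore expected to sit close to compound 2. The expected step is a 1.1-fold lower number from compound 2 to compound 3 (0.02 log units; within the scatter), not expected to pass the scatter in either direction. The estimate for compound 3 is 40000 nM, between 15000 nM and 100000 nM, with a fair chance that this assay again reports only a limit for compound 3.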

Compound 3, half-maximal inhibitory concentration: > 50000 nM
Compound 3 was reported as a limit (the forecaster's own chance of this, stated with the estimate: 40%); at least 1.2-fold (0.09 log units) between middle value and limit.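

Chloro in place of fluoro on an aromatic carbon, meta to a large group, gives an at least 1.1-fold higher number from compound 2 to compound 3 (0.07 log units; that floor lies within the scatter) in this assay, so this exchange shows no lowering of the number. Among the compounds shown here, compound 3 reads only as a limit, which leaves compound 2 with the one true number, and the step from compound 1 to compound 3 cannot be read. Most of the series now reads only as a limit: the limit of > 50000 nM in this assay, at which 2 of the 3 values shown sit.

As far as these compounds go, how far compound 3 actually lies from compound 2 stays open, as does whether any change on this ring can bring the number clearly down. The compounds shown say nothing about an amine or a carboxylic acid on this ring, or about a longer chain in its place.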